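Ethyl for cyclopropyl on the amino nitrogen of compound 3

The source may hold more compounds than are shown below. What is called first, only, known or untested is meant among the compounds shown, and "the series" means these compounds.

In an assay on isolated protein for binding affinity to adenosine receptor A1 (Bos taurus) (on this read-out lower numbers stand for stronger inhibition and higher numbers for weaker inhibition), three compounds of a shared core have been measured. Compound 1 `FC(F)(F)c1ccccc1Cn1nnc2c(NC3CCCC3)nc(-c3ccccc3)nc21` gives 600000 nM. For the measured compounds named here, compound 2 `FC(F)(F)c1ccccc1Cn1nnc2c(NC3CCCCC3)nc(-c3ccccc3)nc21` gives 6800000 nM, and the only one-place step among them, an 11-fold higher number from compound 1 to compound 2 (1.05 log units; beyond the scatter), is large. Compound 3 `c1ccc(Cn2nnc3c(NC4CC4)nc(-c4ccccc4)nc32)cc1` gives 11000000 nM, the highest of the three numbers, though its gap to compound 2 lies within the scatter, while its gap to compound 1 lies beyond it.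

The step from compound 3 to compound 4 `CCNc1nc(-c2ccccc2)nc2c1nnn2Cc1ccccc1` is ethyl in place of cyclopropyl on a nitrogen on an aromatic ring. Going by the values given here, no measured step touches this exact change. Among the compounds with values here, the one step on record at the same nitrogen, from compound 1 to compound 2, enlarged a ring by one carbon and raised the number by a large margin; the present change instead removes a three-membered ring and leaves a two-carbon chain, so that step offers only a loose guide and no firm direction. The account therefore expects a step of a 1.1-fold lower number from compound 3 to compound 4 (0.04 log units; within the scatter), not clearly beyond the scatter.

Compound 4 is accordingly estimated at 10000000 nM in this assay, with a range from 3000000 nM to 35000000 nM.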

Compound 4, inhibition constant: 91000000 nM
The estimate for compound 4 lay 9.1-fold (0.96 log units) below the measured number; measured number above the stated range.
By their numbers in this assay, from the lowest: compound 1; then compounds 2 and 3 (each within the scatter of the next); then compound 4.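

The swap of cyclopropyl for ethyl on a nitrogen on an aromatic ring proved far from neutral in this assay, with an 8.3-fold higher number from compound 3 to compound 4 (0.92 log units; beyond the scatter) as its result. Cyclopropyl, with 3 heavy atoms and a ring, and ethyl, with 2 heavy atoms and no ring, are thus told apart at this nitrogen, even though both numbers lie at the high end of those shown. For the compounds shown here, until now the only step on record at this position was an 11-fold higher number from compound 1 to compound 2 (1.05 log units; beyond the scatter), a change of ring size on a core carrying a trifluoromethyl group that compound 3 and compound 4 lack, whereas this step shows that replacing the ring with an open chain also moves the number beyond the scatter; nothing available here accounts for the rise.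

Going by these compounds, what remains open is whether a longer chain such as propyl or butyl, a branched group such as isopropyl, or a cyclobutyl ring on the same nitrogen would carry the number back down or raise it further. On these data alone, it also remains open whether the swap of cyclopropyl for ethyl would give a step of similar size on a core that carries the trifluoromethyl group.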